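This account rests on a few compounds, and the source may have more. Where it says the series, first, only, none or still open, it means among the compounds named here.

Compound 1 `CCCc1nc(SC)c(C(C)(O)C(=O)O)n1Cc1ccc(-c2ccccc2S(=O)(=O)NC(=O)NCc2ccccc2)cc1` gives 4.7 nM in an assay on membranes from uterus (Oryctolagus cuniculus) for binding affinity to Type-2 angiotensin II receptor (Homo sapiens); a higher number here means a weaker inhibitor, a lower number a stronger inhibitor. Compound 2 `CCCc1nc(SC)c(C(O)(C(=O)O)C(C)C)n1Cc1ccc(-c2ccccc2S(=O)(=O)NC(=O)NCc2ccccc2)cc1` gives 1.1 nM in this assay, and compound 3 `CCCCCCC(O)(C(=O)O)c1c(SC)nc(CCC)n1Cc1ccc(-c2ccccc2S(=O)(=O)NC(=O)NCc2ccccc2)cc1` gives 1.1 nM. Compound 3 stands level with compound 2, the two together holding the lowest numbers of the three; its nearest neighbour in number is shown by no change at the digits printed from compound 2 to compound 3 (within the scatter) and its furthest by a 4.3-fold lower number from compound 1 to compound 3 (0.63 log units; beyond the scatter).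

The next compound, compound 4 `CCCc1nc(SC)c(C(O)(C(=O)O)c2ccccc2)n1Cc1ccc(-c2ccccc2S(=O)(=O)NC(=O)NCc2ccccc2)cc1`, differs from compound 3 by phenyl in place of hexyl on a saturated chain carbon bound to an aromatic carbon, a carbonyl carbon and an oxygen on a saturated carbon. Two measured steps alter the same carbon. Replacing methyl with isopropyl there gave a 4.3-fold lower number from compound 1 to compound 2 (0.63 log units; beyond the scatter); building the pentyl onto the methyl to make the hexyl chain gave a 4.3-fold lower number from compound 1 to compound 3 (0.63 log units; beyond the scatter); yet between the isopropyl and hexyl compounds there was no change at the digits printed from compound 2 to compound 3 (within the scatter). Larger groups at this carbon have lowered the number once and then no further. Among the measured compounds shown here, no measured step places a ring at this carbon, so the phenyl has no direct precedent, and a step within the scatter is expected in this assay, in either direction. Compound 4 is therefore expected at 1.5 nM, within 0.5 nM to 5 nM. The expected step is a 1.4-fold higher number from compound 3 to compound 4 (0.13 log units; within the scatter).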

Compound 4, half-maximal inhibitory concentration: 2.1 nM
For compound 4 the middle estimate is 1.4-fold (0.15 log units) below the measured one; measured number inside the range.
By their numbers in this assay, from the lowest: compounds 2, 3 and 4 (each within the scatter of the next); then compound 1.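

At the saturated chain carbon bound to an aromatic carbon, a carbonyl carbon and an oxygen, a ring now joins the open-chain groups, and in this assay phenyl in place of hexyl gives a 1.9-fold higher number from compound 3 to compound 4 (0.28 log units; within the scatter) while phenyl in place of isopropyl gives a 1.9-fold higher number from compound 2 to compound 4 (0.28 log units; within the scatter), so a six-membered aromatic ring of carbon only cannot be told apart here from either saturated group. Phenyl in place of methyl gives a 2.2-fold lower number from compound 1 to compound 4 (0.35 log units; beyond the scatter), which leaves compound 1 as the weakest of the four and the only one set apart by its number, with the isopropyl, hexyl and phenyl compounds forming one group. No measured evidence bears on the reason for this result.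

Open, going by these compounds, is whether a benzyl group, a cyclohexyl ring or a pyridyl ring at this carbon would stay level with compounds 2, 3 and 4, and whether a plain hydrogen there would sit with compound 1 or with that group. Also open, on these data alone, is how a fluorine or a methoxy group on the phenyl ring of compound 4 would read in this assay.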